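The source may hold more compounds than are shown below. What is called first, only, known or untested is meant among the compounds shown, and "the series" means these compounds.

Compound 1 `COc1ccc(-n2c(SC(C)C(=O)Nc3nc(C)c(Br)cc3Br)nc3ccccc32)cc1` gives 9700 nM in an ADME assay on Vero cells (Chlorocebus sabaeus) for cytotoxicity, read by MTT assay, with a stated time of 24 h (on this read-out lower numbers stand for higher toxicity in this test and higher numbers for lower toxicity in this test), the highest of the two numbers shown; its nearest neighbour is compound 3 `COc1ccc(-n2c(SC(C)C(=O)Nc3ncc(C)cc3Cl)nc3ccccc32)cc1` at 880 nM, a step of an 11-fold lower number from compound 1 to compound 3 (1.04 log units; beyond the scatter). Compound 2 `COc1ccc(-n2c(SC(C)C(=O)Nc3cc(C)no3)nc3ccccc32)cc1` reaches only the limit > 75000 nM in this assay, so its value is a bound, not a number (the limit of > 75000 nM in this assay, at which 1 of the 3 values shown sits). The steps of an at least 7.7-fold higher number from compound 1 to compound 2 (0.88 log units; beyond the scatter) and an at least 85-fold lower number from compound 2 to compound 3 (1.93 log units; beyond the scatter) each swap the whole ring on the amide-type nitrogen. Compound 4 `COc1ccc(-n2c(SC(C)C(=O)Nc3nc(C)c(Cl)cc3Cl)nc3ccccc32)cc1` differs from compound 1 by 3,5-dichloro-6-methylpyridin-2-yl in place of 3,5-dibromo-6-methylpyridin-2-yl on an amide-type nitrogen. Among the compounds with values here, no measured step exchanges only the halogens within the same ring, so none bears directly on this change; a step within the scatter is expected in this assay, in no set direction. Compound 4 is therefore estimated at 9000 nM (range 3500 nM to 25000 nM), meaning a 1.1-fold lower number from compound 1 to compound 4 (0.03 log units; within the scatter).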

Compound 4, half-maximal cytotoxic concentration: 7250 nM
Compound 4: middle estimate off by 1.2-fold (0.09 log units), on the high side; the range from low to high includes it.
By their numbers in this assay, from the lowest: compound 3; then compounds 4 and 1 (each within the scatter of the next). At a limit, above all of these: compound 2.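

In this assay the 3,5-dichloro-6-methylpyridin-2-yl and 3,5-dibromo-6-methylpyridin-2-yl groups on the amide-type nitrogen are not told apart, with a 1.3-fold lower number from compound 1 to compound 4 (0.13 log units; within the scatter) as the step, so the exchange of halogens within this ring leaves the read-out within the scatter. The other ring exchanges stay beyond the scatter, with an 8.2-fold higher number from compound 3 to compound 4 (0.92 log units; beyond the scatter) on one side and an at least 10-fold lower number from compound 2 to compound 4 (1.01 log units; beyond the scatter) on the other. Compound 2 stands at a limit, not a number: the limit of > 75000 nM in this assay, at which 1 of the 4 values shown sits.

Which single difference separates compound 3 from compound 4 stays open. So does the result of a 3,5-dichloropyridin-2-yl group, or of an amino group in place of one chlorine.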